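Shortening the Ether Chain on a Shared Core

The compounds below may be only part of what the source reports. "The series", "measured", "known", "first", "only" and "open" are said of these compounds alone.

Compound 1, `CCCCOc1cc(-c2ccccc2)nc2ccccc12`: 3.8 ug/mL
Compound 2, `CS(=O)(=O)Oc1cc(-c2ccccc2)nc2ccccc12`: 2.8 ug/mL
Compound 3, `c1ccc(COc2cc(-c3ccccc3)nc3ccccc23)cc1`: 1.6 ug/mL

In a functional assay on KB cells (Homo sapiens) for cytotoxicity (on this read-out lower numbers stand for an effect already at smaller amounts and higher numbers for an effect only at larger amounts of compound), compound 3 gives the lowest of the three numbers. Its nearest neighbour is compound 2, but the step of a 1.8-fold lower number from compound 2 to compound 3 (0.24 log units; within the scatter) lies within the scatter, so no order between these two can be claimed. The step of a 2.4-fold lower number from compound 1 to compound 3 (0.38 log units; beyond the scatter) is the only one beyond the scatter, and it is modest.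

Compound 4, `CCCOc1cc(-c2ccccc2)nc2ccccc12`, has not yet been measured. It differs from compound 3 in one place: ethyl in place of phenyl on a saturated chain carbon bound to an oxygen on an aromatic ring. Within the data shown here, the one measured step that bears on this change is the one between compound 1 and compound 3, which runs the same kind of exchange in the opposite direction, phenyl in place of propyl, and gave a 2.4-fold lower number from compound 1 to compound 3 (0.38 log units; beyond the scatter). Reversing that exchange, ethyl in place of phenyl, should therefore move the number back up by a similar, modest amount, towards the value of compound 1, whose butoxy chain is only one carbon longer than the propoxy chain of compound 4.

Compound 4 is thus expected to give 3.5 ug/mL, with a range from 1.8 ug/mL to 7 ug/mL. The expected step is a 2.2-fold higher number from compound 3 to compound 4 (0.34 log units; beyond the scatter).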

Compound 4, half-maximal effective concentration: 4.5 ug/mL
Compound 4: middle estimate off by 1.3-fold (0.11 log units), on the low side; measured number inside the range.
By their numbers in this assay, from the lowest: compounds 3, 2, 1 and 4 (each within the scatter of the next, the first and the last beyond it).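

Exchanging phenyl for ethyl on the saturated chain carbon gives, in this assay, a 2.8-fold higher number from compound 3 to compound 4 (0.45 log units; beyond the scatter) and so shows that compound 3 stands apart from a second open-chain ether, not only from the butyl ether compound 1. Chain length itself makes no readable difference across this pair of chains, since the loss of one carbon gives a 1.2-fold higher number from compound 1 to compound 4 (0.07 log units; within the scatter) and leaves the propoxy and butoxy compounds without an order. Putting propyl in place of methylsulfonyl on the oxygen gives a 1.6-fold higher number from compound 2 to compound 4 (0.21 log units; within the scatter) and therefore separates neither group from the other, so compound 2 remains within the scatter of compound 4, as it does of compound 1 and compound 3.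

The compounds shown leave open whether an ethoxy or a longer chain such as hexyloxy would stay level with compound 1 and compound 4, and whether an amine or a carboxylic acid at the end of the chain, or a chlorine on the benzyl phenyl ring, would shift the number. No measurement here accounts for any of these steps.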